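This account rests on a few compounds, and the source may have more. Where it says the series, first, only, none or still open, it means among the compounds named here.

Compound 1 `Nc1n[nH]c(N)c1/N=N/c1cccc2ccccc12`: > 100000 nM, a limit and not a number
Compound 2 `Nc1n[nH]c(N)c1/N=N/c1cccc([N+](=O)[O-])c1`: 65000 nM

Both compounds were tested in a functional assay on MCF7 cells (Homo sapiens) for antiproliferative activity; a lower number here means a stronger inhibitor, a higher number a weaker inhibitor. Compound 1 is reported only as the limit > 100000 nM. Among the measured compounds shown here, that leaves compound 2, at 65000 nM, with the only true number in this pair, so there is no measured series against which to rank it.

Compound 3 `Nc1n[nH]c(N)c1/N=N/c1cccc(C(=O)O)c1` keeps the shared core of compound 2 and changes in one place: carboxy in place of nitro on an aromatic carbon, meta to a group of 9 heavy atoms (carboxy in place of nitro on an aromatic carbon). For the measured compounds named here, no measured pair of compounds tests this swap, so its effect in this assay cannot be read directly from the data. Going by the values given here, the only anchor is compound 2 at 65000 nM, and a modest shift towards weaker inhibition seems the most reasonable expectation. The expected change, a 1.2-fold higher number from compound 2 to compound 3 (0.09 log units; within the scatter), is small and may not clear the usual scatter. A result reported only as a limit would also fit this expectation. For compound 3 the estimated value is 80000 nM, with an expected range of 30000 nM to 150000 nM.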

Compound 3, half-maximal inhibitory concentration: > 100000 nM
Compound 3 was reported as a limit; the forecaster's own chance of this, stated with the estimate: 40%; at least 1.2-fold (0.09 log units) between middle value and limit.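

Replacing nitro with carboxy on this aromatic carbon, meta to a group of 9 heavy atoms, now has a direct reading in this assay: the swap gives an at least 1.5-fold higher number from compound 2 to compound 3 (0.18 log units; that floor lies within the scatter). Among the compounds shown here, this is the first sign that the carboxy compound does not reach the number of the nitro compound, although the printed figure is only a floor and that floor does not clear the scatter, so the step alone does not firmly separate the two groups. The true size of the step cannot be read, and compound 3 could be only slightly weaker or far weaker, because the result stops at the edge of what was reported: the limit of > 100000 nM in this assay, at which 2 of the 3 values shown sit.

The compounds shown leave open whether other small groups at this same place would give a lower number, for example an amine, a methyl ester or a primary amide. They also leave open whether the number of compound 2 depends on the nitro group specifically, and a ring carrying only a hydrogen at this place, or a nitrile there, would help to settle that question.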